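Bromo to chloro exchange on two related cores

The source may hold more compounds than are shown below. What is called first, only, known or untested is meant among the compounds shown, and "the series" means these compounds.

Measured compounds:
compound 1 `COc1ccc(C2=NN(C3=NC(=O)/C(=C4\C(=O)Nc5ccc(Br)cc54)S3)C(c3ccc(OC)cc3)C2)cc1`: 410 nM
compound 2 `COc1ccc(C2=NN(C3=NC(=O)/C(=C4\C(=O)Nc5ccc(Cl)cc54)S3)C(c3ccc(OC)cc3)C2)cc1`: 380 nM
compound 3 `CN(C)c1ccc(C2CC(c3ccccc3)=NN2C2=NC(=O)/C(=C3\C(=O)Nc4ccc(Br)cc43)S2)cc1`: 460 nM

In a functional assay on cells (Melanoma cell, Homo sapiens) for cytotoxicity, read by sulforhodamine B assay, with a stated time of 48 h (a lower number here means a stronger inhibitor of growth, a higher number a weaker inhibitor of growth), compound 1 gives 410 nM. Compound 2 carries chloro in place of bromo on an aromatic carbon and gives 380 nM; the step of a 1.1-fold lower number from compound 1 to compound 2 (0.03 log units; within the scatter) is within the scatter, so the two values are read as equal. Compound 3 differs from compound 1 in more than one place; the difference between the two cores is not broken down here. In this assay compound 3 gives 460 nM, and its gaps to compound 1 and to compound 2 are both within the scatter, so no order among the three is claimed.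

Compound 4 `CN(C)c1ccc(C2CC(c3ccccc3)=NN2C2=NC(=O)/C(=C3\C(=O)Nc4ccc(Cl)cc43)S2)cc1` has not been measured. It differs from compound 3 by chloro in place of bromo on an aromatic carbon, the same change as that from compound 1 to compound 2, at a place described in the same words. The expected step of a 1.1-fold lower number from compound 3 to compound 4 (0.03 log units; within the scatter) is estimated to be small, resting on the near-flat step a 1.1-fold lower number from compound 1 to compound 2 (0.03 log units; within the scatter) seen on the other core. Compound 4 is therefore expected to give about 430 nM, with a likely range from 250 nM to 750 nM.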

Compound 4, concentration for total growth inhibition: 570 nM
Beside the measured number, compound 4's estimate is 1.3-fold (0.12 log units) below it; the range from low to high includes it.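

In this assay, chloro in place of bromo on the core of compound 3 gives a 1.2-fold higher number from compound 3 to compound 4 (0.09 log units; within the scatter), so the two values are read as equal. Set beside the earlier step, this step does not differ from it: the same change on two cores in this assay, a 1.1-fold lower number (0.03 log units; within the scatter) from compound 1 to compound 2 and a 1.2-fold higher number (0.09 log units; within the scatter) from compound 3 to compound 4, 1.3-fold (0.13 log units) apart, within the scatter of two such steps. On these two cores, the exchange carries across with no step beyond the scatter and no reliable direction on either core, but this does not show that the two halogens are interchangeable on other cores or in other assays.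

The compounds shown carry only bromo or chloro at this place, so the outcome with fluoro, methyl, methoxy or an amine there remains open. Also open, from the compounds shown here alone, is whether the exchange stays this small on a core bearing a morpholine or a carboxylic acid in place of the methoxy or dimethylamino groups.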